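3-chlorophenyl to 3-fluorophenyl: working notes

The source may report more compounds than this note shows. Statements on the series, on what has been measured and on what is new or still open speak of the compounds shown alone.

Values in a functional assay (aorta) for inhibition, with Rattus norvegicus as the target, with a stated time of 8 days; a higher number here means a weaker inhibitor, a lower number a stronger inhibitor:
- compound 1 `Cc1nsc(-c2ccc(N3CCN(c4cccc(Cl)c4)CC3)nn2)n1`: 0.6 nM
- compound 2 `CCc1nsc(-c2ccc(N3CCN(c4cccc(C(F)(F)F)c4)CC3)nn2)n1`: 8 nM
- compound 3 `CNc1nsc(-c2ccc(N3CCN(c4cccc(C(F)(F)F)c4)CC3)nn2)n1`: 3 nM

Compound 1 has the lowest of the three numbers, with compound 3 nearest at 3 nM and compound 2 furthest at 8 nM, both gaps beyond the scatter.

Compound 4 `Cc1nsc(-c2ccc(N3CCN(c4cccc(F)c4)CC3)nn2)n1` is still to be measured and differs from compound 1 in one place: fluoro in place of chloro on an aromatic carbon. This is fluoro in place of chloro on an aromatic carbon, meta to a large group.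

Among the measured compounds shown here, the only measured single-place step is a 2.7-fold lower number from compound 2 to compound 3 (0.43 log units; beyond the scatter), a modest one. It swaps ethyl for methylamino, so it bears on the present change only as a guide to size. For the measured compounds named here, no measured pair exchanges chloro and fluoro, and the direction is therefore uncertain. With compound 1 at 0.6 nM as the lowest of the three, a higher number is the likelier outcome.

A modest step is expected in this assay, estimated as a 2.5-fold higher number from compound 1 to compound 4 (0.40 log units; beyond the scatter) and pointing to a weaker inhibitor. The estimate for compound 4 is 1.5 nM with an expected range of 0.5 nM to 5 nM in this series.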

Compound 4, half-maximal inhibitory concentration: 6 nM
Estimate against measurement, compound 4: 4.0-fold (0.60 log units) below, and the stated range ends below it.
By their numbers in this assay, from the lowest: compound 1; then compounds 3, 4 and 2 (each within the scatter of the next, the first and the last beyond it).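

In this assay, fluoro in place of chloro on an aromatic carbon, meta to a large group, gives a 10-fold higher number from compound 1 to compound 4 (1.00 log units; beyond the scatter), so this position does not treat the two halogens alike. The change replaces one heavy atom with another, and the counted hydrogen-bond donors, hydrogen-bond acceptors and net charge stay the same, yet the step lies beyond the scatter. The earlier step, a 2.7-fold lower number from compound 2 to compound 3 (0.43 log units; beyond the scatter), concerned a different place in the molecule and gave no reading of the substituent on the phenyl ring, whereas this pair shows that the read-out responds to that substituent, though no measurement shown here bears on the reason for the step.

The compounds shown leave open how other groups at this position would read against chloro and fluoro, for example bromo, methoxy, nitrile or a plain hydrogen. They also leave open whether the same exchange would give a similar step with ethyl or methylamino on the core, and how trifluoromethyl compares with chloro when everything else is held constant, since compound 1 differs from compound 2 and compound 3 in more than one place.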